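Shifting Two Fluorines on the Ring Amine Substituent

This account rests on a few compounds, and the source may have more. Where it says the series, first, only, none or still open, it means among the compounds named here.

Compound 2 `Nc1scc(CN2CCN(c3ccc(F)cc3F)CC2)c1C(=O)c1ccc(Cl)cc1` carries a 2,4-difluorophenyl on an amine nitrogen in a ring. Among the compounds with values here, in an assay on CHO cells for displacement of a labelled ligand from adenosine receptor A3 (Homo sapiens), read by scintillation counting, with a stated time of 120 min, tested at 10 uM (a lower number here means less inhibition, a higher number more inhibition at the concentration tested (going by the name of the read-out)), compound 2 gives 0%, which places it level with its only measured neighbour. That neighbour, compound 1 `Nc1scc(CN2CCN(c3cccc(C(F)(F)F)c3)CC2)c1C(=O)c1ccc(Cl)cc1`, bears 3-(trifluoromethyl)phenyl at the same place and gives 0% in this assay; the step of no change at the digits printed from compound 1 to compound 2 (within the scatter) is flat within the scatter. Compound 3 `Nc1scc(CN2CCN(c3cc(F)cc(F)c3)CC2)c1C(=O)c1ccc(Cl)cc1` differs from compound 2 by 3,5-difluorophenyl in place of 2,4-difluorophenyl on an amine nitrogen in a ring. Within the data shown here, only one measured step touches this position, and it produced no movement at all, so there is no basis in the data for any shift in either direction. The step to compound 3 is therefore expected to be no change at the digits printed from compound 2 to compound 3 (within the scatter), nothing beyond the scatter. Compound 3 is estimated at 0% in this assay, with a range from -10% to 12%.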

Compound 3, a percentage reported as inhibition, at one concentration (the size of the read-out at that concentration, not a potency): 2%
Beside the measured number, compound 3's estimate is 2 percentage points below it, within the range that was stated.
By their numbers in this assay, from the lowest: compounds 1, 2 and 3 (each within the scatter of the next).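

The change of 2,4-difluorophenyl to 3,5-difluorophenyl rearranges the same atoms and gives a number 2 percentage points higher from compound 2 to compound 3 (within the scatter) in this assay, while the change of 3-(trifluoromethyl)phenyl to 3,5-difluorophenyl gives a number 2 percentage points higher from compound 1 to compound 3 (within the scatter). All three groups on this amine nitrogen therefore stand within the scatter of one another, and moving the two fluorines on the ring has now been seen to leave the read-out flat, as exchanging the trifluoromethyl group for fluorines had. No measurement is available that would explain this flatness.

The compounds shown leave open whether a pyridine ring, a benzyl group or a phenyl ring carrying a methoxy group or an amine would move the read-out at this position. They also leave open whether a change elsewhere on the shared core would do so.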